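Swapping the Aryl Group on the Five-Membered Ring Nitrogen

This account rests on a few compounds, and the source may have more. Where it says the series, first, only, none or still open, it means among the compounds named here.

Of the compounds shown here, three have been tested in a functional assay on A549 cells (Homo sapiens) for antiproliferative activity, read by MTT assay, with a stated time of 48 h; a higher number here means a weaker inhibitor, a lower number a stronger inhibitor. Compound 1 `N#CC1=C(N)Oc2c(N)cc3nc4ccccc4nc3c2C12C(=O)N(Cc1cnnn1-c1ccccc1Br)c1ccccc12` gives 27400 nM. Compound 2 `N#CC1=C(N)Oc2c(N)cc3nc4ccccc4nc3c2C12C(=O)N(Cc1cnnn1-c1ccc([N+](=O)[O-])cc1)c1ccccc12` reaches only the limit of the assay, > 50000 nM. Compound 3 `Cc1ccc(-n2nncc2CN2C(=O)C3(C(C#N)=C(N)Oc4c(N)cc5nc6ccccc6nc5c43)c3ccccc32)cc1C` likewise returns only a limit, > 50000 nM. Compound 3 thus stands at the ceiling of what this assay reports, a position it shares with one other value, as summarised by the limit of > 50000 nM in this assay, at which 2 of the 3 values shown sit. Both measured steps away from compound 1 run toward a weaker inhibitor, each only as a floor: an at least 1.8-fold higher number from compound 1 to compound 2 (0.26 log units; that floor lies within the scatter) and an at least 1.8-fold higher number from compound 1 to compound 3 (0.26 log units; that floor lies within the scatter). Between the two limits, a step that the two limits leave unreadable from compound 2 to compound 3.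

Compound 4 `COc1ccc(OC)c(-n2nncc2CN2C(=O)C3(C(C#N)=C(N)Oc4c(N)cc5nc6ccccc6nc5c43)c3ccccc32)c1` differs from compound 3 by a change on the aromatic nitrogen: 2,5-dimethoxyphenyl in place of 3,4-dimethylphenyl on an aromatic nitrogen. Among the measured compounds shown here, no measured step tests this exchange directly. For the measured compounds named here, what the data do show is that every aryl variation so far, starting from compound 1, ended at or near the ceiling of this assay, so an expectation for compound 4 can only be anchored to the limit of compound 3. The step expected for compound 4 is an at least 1.1-fold lower number from compound 3 to compound 4 (0.04 log units; that floor lies within the scatter), meaning no change beyond the scatter. Compound 4 is therefore estimated at 45000 nM, with a range from 15000 nM to 150000 nM, and a fair chance that this assay again reports only its limit.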

Compound 4, half-maximal inhibitory concentration: 28100 nM
Beside the measured number, compound 4's estimate is 1.6-fold (0.20 log units) above it; measured number inside the range.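

Compound 4 is the second compound in this set, after compound 1, to return a number rather than a limit in this assay, so a readable value at this position does not depend on 2-bromophenyl. The direct comparison with compound 1 shows a 1.0-fold higher number from compound 1 to compound 4 (0.01 log units; within the scatter), meaning that 2,5-dimethoxyphenyl and 2-bromophenyl cannot be told apart here. The other two comparisons give only floors, an at least 1.7-fold lower number from compound 3 to compound 4 (0.25 log units; that floor lies within the scatter) and an at least 1.7-fold lower number from compound 2 to compound 4 (0.25 log units; that floor lies within the scatter), and neither establishes a difference beyond the scatter, with the true size of both steps hidden because compound 2 and compound 3 are known only as limits: the limit of > 50000 nM in this assay, at which 2 of the 4 values shown sit.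

On these data alone, whether an unsubstituted phenyl or a 2-methoxyphenyl group on the same nitrogen would also give a readable number remains open. So does the outcome of replacing the aryl group with a non-aromatic substituent such as a cyclohexyl ring or an n-butyl chain.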